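Acetamido replaces aminomethyl on the sulfur chain

The source may report more compounds than this note shows. Statements on the series, on what has been measured and on what is new or still open speak of the compounds shown alone.

In a functional assay on HT cells (Homo sapiens) for antiproliferative activity, read by fluorescence, with a stated time of 72 h (a lower number here means a stronger inhibitor of growth, a higher number a weaker inhibitor of growth), compound 1 (`CC(C)c1n[nH]c2c(NCc3ccc(-c4ccccn4)cc3)nc(SC3CCCC3O)nc12`) reads 567 nM while compound 2 (`CC(C)c1n[nH]c2c(NCc3ccc(-c4ccccn4)cc3)nc(SCCCN)nc12`) reads 120 nM and so holds the lower of the two numbers. The step of a 4.7-fold lower number from compound 1 to compound 2 (0.67 log units; beyond the scatter) comes with 3-aminopropyl in place of 2-hydroxycyclopentyl on a sulfur. Compound 3 (`CC(=O)NCCSc1nc(NCc2ccc(-c3ccccn3)cc2)c2[nH]nc(C(C)C)c2n1`) alters that chain again, with acetamido in place of aminomethyl on a saturated chain carbon, two bonds along the chain from a sulfur. Among the compounds with values here, no measured step makes this change directly, and only the one step above bears on it. The expectation rests on compound 1, which has no amine on that chain and reads 567 nM in the same assay. A modest step towards a higher number is therefore expected, though one step is thin evidence. The estimate is a 2.9-fold higher number from compound 2 to compound 3 (0.46 log units; beyond the scatter) as the expected change. Compound 3 is estimated at 350 nM (range 130 nM to 900 nM).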

Compound 3, concentration for 50% growth inhibition: 71 nM
For compound 3 the middle estimate is 4.9-fold (0.69 log units) above the measured one; measured number outside the range, below it.
By their numbers in this assay, from the lowest: compounds 3 and 2 (each within the scatter of the next); then compound 1.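

In this assay, the acetamido group on this chain reads a 1.7-fold lower number from compound 2 to compound 3 (0.23 log units; within the scatter) and so leaves the number level with that of the aminomethyl end. Within the data shown here, the lower number of compound 2 therefore does not depend on a free amine at the end of the chain, which the single earlier step could not show. With an 8.0-fold lower number from compound 1 to compound 3 (0.90 log units; beyond the scatter) as well, both open chains on the sulfur stand apart from 2-hydroxycyclopentyl, and no measurement here accounts for this result.

The compounds shown leave open whether the change from compound 1 owes more to losing the ring or to losing the hydroxyl group, since the two go together in these steps. They also do not tell whether a carboxylic acid or a longer chain ending in acetamido would read like compound 3.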